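A few compounds are considered here, and "the series" means these few. Any claim that something is new, unique, unknown or untested is made for them only; others in the source may bear on it.

Among the compounds with values here, only two compounds have been tested so far in a functional assay (strain AB) with Danio rerio as the target, read by microscopy, with a stated time of 1 h; on this read-out lower numbers stand for an effect already at smaller amounts and higher numbers for an effect only at larger amounts of compound. Compound 1 `CCN1CCc2c(sc(NC=O)c2C(N)=O)C1` gives > 25000 nM, which is a limit of the assay and not a number. Compound 2 `CCN1CCc2c(sc(NC(=O)Nc3ccc(Cl)cc3)c2C#N)C1` gives > 25000 nM, which is likewise a limit and not a number. The whole record so far is the limit of > 25000 nM in this assay, at which 2 of the 2 values shown sit. Within the data shown here, no measured step between two compounds is available as a guide, so compound 2 offers only a ceiling and no true starting value.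

Compound 3 `CCN1CCc2c(sc(NC(=O)Nc3ccc(Cl)cc3)c2C(=O)OC)C1` differs from compound 2 in one place, with methoxycarbonyl in place of cyano on an aromatic carbon. The rest of the structure stays the same.

Compound 2 sits at > 25000 nM, so any real number for compound 3 could only point towards an effect at smaller amounts. A moderate shift in that direction is expected, though compound 3 may well stop at the same limit. The expected step is an at least 2.0-fold lower number from compound 2 to compound 3 (0.31 log units; beyond the scatter), and it is a loose estimate. For compound 3 the estimated value is 12000 nM, with an expected range from 2000 nM to 25000 nM.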

Compound 3, half-maximal effective concentration: > 25000 nM
Compound 3 gave a limit, no number (the forecaster's own chance of this, stated with the estimate: 55%); at least 2.0-fold (0.31 log units) between middle value and limit.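

Compound 2 and compound 3 both end at a limit of the assay and not at a number, so no step can be read for methoxycarbonyl in place of cyano. The compounds shown leave open whether any change to the shared core would give a real number, and the record so far is a single ceiling: the limit of > 25000 nM in this assay, at which 3 of the 3 values shown sit.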